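This account rests on a few compounds, and the source may have more. Where it says the series, first, only, none or still open, it means among the compounds named here.

In a functional assay on HEK293 cells for positive allosteric modulation of metabotropic glutamate receptor 5 (Homo sapiens), read by FLIPR and calcium flux (on this read-out higher numbers stand for an effect only at larger amounts of compound and lower numbers for an effect already at smaller amounts), compound 3 `O=C(COCc1cnccn1)N1CCN(c2ccc(Cl)cc2Cl)CC1` gives 5200 nM, the highest of the three numbers measured. Compound 1 `O=C(COCc1ccccc1)N1CCN(c2ccc(F)cc2)CC1` gives 1100 nM and compound 2 `O=C(COCc1ccccc1)N1CCN(c2ccc(Cl)cc2Cl)CC1` gives 1000 nM; the step of a 1.1-fold lower number from compound 1 to compound 2 (0.04 log units; within the scatter) lies within the scatter, whereas the step of a 5.2-fold higher number from compound 2 to compound 3 (0.72 log units; beyond the scatter) is a clear rise. Compound 4 `O=C(COCc1cscn1)N1CCN(c2ccc(Cl)cc2Cl)CC1` differs from compound 3 by 1,3-thiazol-4-yl in place of pyrazin-2-yl on a saturated chain carbon bound to an oxygen on a saturated carbon. Among the compounds with values here, only the step from compound 2 to compound 3 touches this position, and it shows that swapping the ring there can move the number beyond the scatter. Because of a 5.2-fold higher number from compound 2 to compound 3 (0.72 log units; beyond the scatter) a modest shift back toward the lower numbers is expected, giving an estimated step of a 1.7-fold lower number from compound 3 to compound 4 (0.24 log units; within the scatter). Compound 4 is therefore expected at about 3000 nM, within 1000 nM to 9000 nM.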

Compound 4, half-maximal effective concentration: 290 nM
The estimate for compound 4 lay 10-fold (1.01 log units) above the measured number; measured number below the stated range.
By their numbers in this assay, from the lowest: compound 4; then compounds 2 and 1 (each within the scatter of the next); then compound 3.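

Putting 1,3-thiazol-4-yl in place of pyrazin-2-yl gives an 18-fold lower number from compound 3 to compound 4 (1.25 log units; beyond the scatter) in this assay and counts as a large step. Set against the phenyl of the earlier pair, 1,3-thiazol-4-yl gives a 3.4-fold lower number from compound 2 to compound 4 (0.54 log units; beyond the scatter) as well, so swapping the ring at this position can lower the number, not only raise it. No measurement offered here explains the difference between these rings.

Still open, on these data alone, is whether a furan-2-yl or 1,3-oxazol-4-yl ring, or a longer chain carrying the 1,3-thiazol-4-yl, would keep the low number. Also open, as far as these compounds go, is whether this ring acts the same with 4-fluorophenyl on the amine nitrogen.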